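A few compounds are considered here, and "the series" means these few. Any claim that something is new, unique, unknown or untested is made for them only; others in the source may bear on it.

Measured compounds:
- compound 1 `CC(C(=O)Nc1cc(C2CC2)[nH]n1)c1ccc(N2CCCC2)cc1`: 370 nM
- compound 2 `CC(C(=O)Nc1cc(C2CC2)[nH]n1)c1ccc(-n2ccnc2O)cc1`: 6980 nM
- compound 3 `CC(C(=O)Nc1cc(C2CC2)[nH]n1)c1ccc(N2C(=O)CCC2c2ccccc2)cc1`: 15300 nM

In a functional assay on A2780 cells (Homo sapiens) for inhibition (a higher number here means a weaker inhibitor, a lower number a stronger inhibitor), compound 1 gives the lowest number of the three. Exchange of the group on the aromatic carbon gave a 19-fold higher number from compound 1 to compound 2 (1.28 log units; beyond the scatter); compound 3, with its larger replacement, gives 15300 nM against compound 1 at 370 nM. Compound 4 `CC(C(=O)Nc1cc(C2CC2)[nH]n1)c1ccc(N2CCCS2(=O)=O)cc1` differs from compound 1 in one place: a group of 7 heavy atoms (3 carbon, 1 nitrogen, 2 oxygen, 1 sulfur; one five-membered non-aromatic ring with 2 hetero atoms) in place of a group of 5 heavy atoms (4 carbon, 1 nitrogen; one five-membered non-aromatic ring with 1 hetero atom), on an aromatic carbon. Among the compounds with values here, the only step of this kind, from compound 1 to compound 2, was large and weakening, and compound 3 points the same way, so a clearly higher number is expected for compound 4 in this assay, though the size is uncertain. Compound 4 is therefore estimated at 4000 nM (range 1200 nM to 15000 nM), a step of an 11-fold higher number from compound 1 to compound 4 (1.03 log units; beyond the scatter).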

Compound 4, half-maximal inhibitory concentration: 5240 nM
Compound 4: the middle estimate sits 1.3-fold (0.12 log units) below what was measured; the range from low to high includes it.
By their numbers in this assay, from the lowest: compound 1; then compounds 4 and 2 (each within the scatter of the next); then compound 3.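

In this assay, replacing pyrrolidin-1-yl with the five-membered ring holding sulfur and two oxygens gives a 14-fold higher number from compound 1 to compound 4 (1.15 log units; beyond the scatter) at this place, so a second replacement on this aromatic carbon also loses activity. Compounds with a non-aromatic and an aromatic replacement are not separated, with a 1.3-fold lower number from compound 2 to compound 4 (0.12 log units; within the scatter) between them. Nothing at hand explains either step. Open, on these data alone, is whether piperidin-1-yl, morpholin-4-yl or dimethylamino at this place would stay near compound 1 at 370 nM in this assay or rise likewise.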